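This account rests on a few compounds, and the source may have more. Where it says the series, first, only, none or still open, it means among the compounds named here.

Going by the values given here, in a functional assay on MCF7 cells (Homo sapiens) for cytotoxicity, read by MTT assay, with a stated time of 72 h (a higher number here means a weaker inhibitor, a lower number a stronger inhibitor), compound 3 `Cc1cccc(-c2ccnc(C(=O)Nc3ccc(Oc4ccnc5[nH]ccc45)c(F)c3)c2)c1` gives 9120 nM, the only number in the set. Compound 2 `O=C(Nc1ccc(Oc2ccnc3[nH]ccc23)c(F)c1)c1cc(-c2ccccc2)ccn1` reaches only the limit > 10000 nM. Compound 1 `Cc1ccc(-c2ccnc(C(=O)Nc3ccc(Oc4ccnc5[nH]ccc45)cc3)c2)cc1`, which carries the 4-methylphenyl group but no fluorine, also stops at the limit > 10000 nM. Among the compounds with values here, the one measured step, an at least 1.0-fold lower number from compound 2 to compound 3 (0.04 log units; that floor lies within the scatter), lies within the scatter. Compound 4 `Cc1ccc(-c2ccnc(C(=O)Nc3ccc(Oc4ccnc5[nH]ccc45)c(F)c3)c2)cc1` differs from compound 3 by 4-methylphenyl in place of 3-methylphenyl on an aromatic carbon. Since compound 1 sits at the limit of > 10000 nM in this assay, at which 2 of the 3 values shown sit, and an at least 1.0-fold lower number from compound 2 to compound 3 (0.04 log units; that floor lies within the scatter) was small, no shift beyond the scatter is expected in this assay, and a limit is again likely. Compound 4 is therefore estimated at 10000 nM, with a range from 5000 nM to 20000 nM. The expected step is a 1.1-fold higher number from compound 3 to compound 4 (0.04 log units; within the scatter).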

Compound 4, half-maximal inhibitory concentration: 8430 nM
Beside the measured number, compound 4's estimate is 1.2-fold (0.07 log units) above it; the range from low to high includes it.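

In this assay, 4-methylphenyl and 3-methylphenyl on this carbon, opposite the ring nitrogen, cannot be told apart: a 1.1-fold lower number from compound 3 to compound 4 (0.03 log units; within the scatter). The other two steps reaching compound 4 are floors only, an at least 1.1-fold lower number from compound 2 to compound 4 (0.07 log units; that floor lies within the scatter) and an at least 1.1-fold lower number from compound 1 to compound 4 (0.07 log units; that floor lies within the scatter), so neither the methyl nor the fluoro can be credited with an effect. Compounds 1 and 2 remain limits of the assay, not numbers: the limit of > 10000 nM in this assay, at which 2 of the 4 values shown sit. Going by these compounds, whether an amine or a carboxylic acid on this phenyl ring, or a longer chain in place of the methyl, would move the number beyond the scatter stays open.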